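Pyridyl isomer swap in the naphthol series

The source may report more compounds than this note shows. Statements on the series, on what has been measured and on what is new or still open speak of the compounds shown alone.

Compound 2 `Oc1c(Cc2ccccn2)ccc2ccccc12` gives 390 nM in an assay on RBL-1 cells with Polyunsaturated fatty acid 5-lipoxygenase (Rattus norvegicus) as the target (a lower number here means a stronger inhibitor, a higher number a weaker inhibitor), and stands highest of the two numbers; compound 1 `C=CCc1ccc2ccccc2c1O` gives 56 nM, so that a 7.0-fold higher number from compound 1 to compound 2 (0.84 log units; beyond the scatter) lies beyond the scatter. Compound 3 `Oc1c(Cc2ccncc2)ccc2ccccc12` differs from compound 2 by pyridin-4-yl in place of pyridin-2-yl on a saturated chain carbon bound to an aromatic carbon. Within the data shown here, no measured step exchanges one pyridinyl for another; the single step on record, from compound 1 to compound 2, replaced vinyl with pyridin-2-yl and bears on this change only indirectly. A step within the scatter is therefore expected, a 1.0-fold higher number from compound 2 to compound 3 (0.01 log units; within the scatter). Compound 3 is estimated at 400 nM, range 130 nM to 1200 nM.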

Compound 3, half-maximal inhibitory concentration: 140 nM
The estimate for compound 3 lay 2.9-fold (0.46 log units) above the measured number; measured number inside the range.
By their numbers in this assay, from the lowest: compound 1; then compound 3; then compound 2.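

In this assay the isomer swap on the saturated chain carbon bound to an aromatic carbon is readable: pyridin-4-yl in place of pyridin-2-yl gives a 2.8-fold lower number from compound 2 to compound 3 (0.44 log units; beyond the scatter), so the place of the ring nitrogen counts here although the atoms are the same. Neither pyridinyl reaches vinyl, with pyridin-4-yl in place of vinyl giving a 2.5-fold higher number from compound 1 to compound 3 (0.40 log units; beyond the scatter), though that gap is smaller than for pyridin-2-yl. No evidence is available that accounts for the gap between the isomers. Still open, on these data alone, is where pyridin-3-yl falls relative to these two isomers, and whether phenyl on the same carbon would come closer to vinyl.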